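Replacing 3-aminophenyl with 3-(methylamino)propyl in compound 2

The source may report more compounds than this note shows. Statements on the series, on what has been measured and on what is new or still open speak of the compounds shown alone.

In a functional assay on SK-BR-3 cells (Homo sapiens) for cytotoxicity, read by MTT assay, with a stated time of 72 h (a higher number here means a weaker inhibitor, a lower number a stronger inhibitor), compound 1 `N[C@H]1CC[C@H](Nc2c(C(=O)NCc3ccc(F)cc3)nc(N3CCCCS3(=O)=O)c3cccnc23)CC1` gives 8500 nM, and compound 3 `N[C@H]1CC[C@H](Nc2c(C(=O)NCc3ccc(Cl)cc3Cl)nc(Br)c3cccnc23)CC1` gives 6000 nM. Compound 2 `Nc1cccc(Nc2c(C(=O)NCc3ccc(F)cc3)nc(Br)c3cccnc23)c1` reads > 10000 nM, which is a limit of the assay and not a number. It therefore has no exact place among the three. Compound 4 `CNCCCNc1c(C(=O)NCc2ccc(F)cc2)nc(Br)c2cccnc12` keeps the rest of compound 2 but carries 3-(methylamino)propyl in place of 3-aminophenyl on a nitrogen on an aromatic ring. For the measured compounds named here, no measured step covers this change, so the expectation rests on compound 3, which also lacks 3-aminophenyl and gives 6000 nM. A modest move towards stronger inhibition in this assay is expected, an at least 1.5-fold lower number from compound 2 to compound 4 (0.18 log units; that floor lies within the scatter). The estimate for compound 4 is 6500 nM, with an expected range of 2500 nM to 10000 nM.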

Compound 4, half-maximal inhibitory concentration: 1000 nM
Compound 4: middle estimate off by 6.5-fold (0.81 log units), on the high side; measured number outside the range, below it.
By their numbers in this assay, from the lowest: compound 4; then compounds 3 and 1 (each within the scatter of the next). At a limit, above all of these: compound 2.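

In this assay, the group on this nitrogen on an aromatic ring clearly matters: 3-(methylamino)propyl in place of 3-aminophenyl gives an at least 10-fold lower number from compound 2 to compound 4 (1.00 log units; beyond the scatter). For the compounds shown here, the earlier compounds offered no measured step at this position, so this is the first direct reading of a change there. The true size of the step stays open-ended, as one end of it is a limit of the assay: the limit of > 10000 nM in this assay, at which 1 of the 4 values shown sits.

The compounds shown leave open whether the gain follows the open chain or the methylamino end. A shorter or longer chain, or a dimethylamino group at its end, would help separate the two.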